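Pyridin-3-yl in Place of 4-Chlorophenyl: Outlook for Compound 4

The compounds below may be only part of what the source reports. "The series", "measured", "known", "first", "only" and "open" are said of these compounds alone.

Among the compounds with values here, compound 3 `O=C(CCc1ccc(-c2ccc(Cl)cc2)cc1)N1CCCC1` is the only member with a number in an assay on HEK293 cells for inhibition of N-acylethanolamine-hydrolyzing acid amidase (Rattus norvegicus), read by LC-MS, with a stated time of 30 min; on this read-out higher numbers stand for weaker inhibition and lower numbers for stronger inhibition: compound 3 gives 48600 nM. Compound 1 `Cc1ccccc1-c1ccc(CCC(=O)N2CCCC2)cc1` sits at the limit of > 100000 nM in this assay. Compound 2 `O=C(CCc1ccc(-c2ccccc2Cl)cc1)N1CCCC1` likewise returns only the limit > 100000 nM. Because of the limit of > 100000 nM in this assay, at which 2 of the 3 values shown sit, the step that the two limits leave unreadable from compound 1 to compound 2 cannot be read, whereas an at least 2.0-fold lower number from compound 1 to compound 3 (0.31 log units; beyond the scatter) and an at least 2.0-fold lower number from compound 2 to compound 3 (0.31 log units; beyond the scatter) are both readable. Compound 4 `O=C(CCc1ccc(-c2cccnc2)cc1)N1CCCC1` differs from compound 3 by pyridin-3-yl in place of 4-chlorophenyl on an aromatic carbon. Within the data shown here, no measured step exchanges a ring of carbon only for one with a hetero atom, and the two readable steps show only that compound 3 stands lower than the limit. A number near that limit is therefore expected for compound 4, the estimated step of a 1.5-fold higher number from compound 3 to compound 4 (0.19 log units; within the scatter) possibly exceeding the scatter toward weaker inhibition. Compound 4 is estimated at 75000 nM, between 25000 nM and 250000 nM.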

Compound 4, half-maximal inhibitory concentration: > 100000 nM
Compound 4: only a limit was reported; the forecaster's own chance of this, stated with the estimate: 45%; middle value at least 1.3-fold (0.12 log units) away from the limit.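

In this assay, within the data shown here, pyridin-3-yl in place of 4-chlorophenyl gives an at least 2.0-fold higher number from compound 3 to compound 4 (0.31 log units; beyond the scatter), the first readable exchange at this position of a ring of carbon only for one with a hetero atom. Among these compounds, the value of compound 4 is only a limit, so compound 3 remains the only member with a number. The steps to compound 4 from compound 1 and compound 2 cannot be read because both ends are limits: the limit of > 100000 nM in this assay, at which 3 of the 4 values shown sit.

The readable step combines loss of the chlorine with entry of the ring nitrogen, and the compounds shown do not separate the two. Unsubstituted phenyl and 6-chloropyridin-3-yl at this position remain open.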